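From ethyl to 4-methoxyphenyl: an unmeasured step

The compounds below may be only part of what the source reports. "The series", "measured", "known", "first", "only" and "open" are said of these compounds alone.

- compound 1 `CCNC(=O)NOCc1ccc(/C=C/C(=O)NO)cc1` gives 14000 nM
- compound 2 `Cc1cc(C)c(NC(=O)NOCc2ccc(/C=C/C(=O)NO)cc2)c(C)c1` gives 3490 nM

In a functional assay on CAL-27 cells (Homo sapiens) for antiproliferative activity, read by MTT assay, with a stated time of 72 h (a lower number here means a stronger inhibitor, a higher number a weaker inhibitor), compound 1 has the higher of the two numbers, which makes it the weaker inhibitor of this pair. Compound 3 `COc1ccc(NC(=O)NOCc2ccc(/C=C/C(=O)NO)cc2)cc1` keeps the core of compound 1 and alters a single group on an amide-type nitrogen. The change is 4-methoxyphenyl in place of ethyl on an amide-type nitrogen and the rest of the molecule stays the same.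

Among the compounds with values here, the one measured step bearing on this is a 4.0-fold lower number from compound 1 to compound 2 (0.60 log units; beyond the scatter) and it also replaces ethyl with a substituted phenyl group, 2,4,6-trimethylphenyl. A single step from a different group is thin evidence, so a similar modest drop is expected, with wide uncertainty. The estimated change is a 3.5-fold lower number from compound 1 to compound 3 (0.54 log units; beyond the scatter) for now. For compound 3 the expected value is 4000 nM with an estimated range from 1500 nM to 11000 nM in this comparison.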

Compound 3, half-maximal inhibitory concentration: 1700 nM
Compound 3: the middle estimate sits 2.4-fold (0.37 log units) above what was measured, and the stated range covers the measured number.
By their numbers in this assay, from the lowest: compound 3; then compound 2; then compound 1.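

Replacing ethyl with 4-methoxyphenyl on this amide-type nitrogen gives an 8.2-fold lower number from compound 1 to compound 3 (0.92 log units; beyond the scatter) in this assay, so the earlier drop with 2,4,6-trimethylphenyl is no longer a lone case: both aromatic groups shown here sit below ethyl. The two aromatic groups are also not interchangeable, since the change between them gives a 2.1-fold lower number from compound 2 to compound 3 (0.31 log units; beyond the scatter) and is printed as beyond the scatter, though it is much the smaller step. No measured evidence is available to explain either step.

The compounds shown leave open whether a ring is needed at all, or whether a longer chain such as n-hexyl would lower the number as well. They also leave open how plain phenyl, with no methoxy or methyl groups, compares with these two rings.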